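This account rests on a few compounds, and the source may have more. Where it says the series, first, only, none or still open, it means among the compounds named here.

Measured compounds:
- Compound 1, `CCc1ccccc1N(CC(=O)OCc1ccc(OC)cc1)S(=O)(=O)c1ccc(C)cc1`: 63 nM; 63.1 nM (2 entries)
- Compound 2, `CCOc1ccc(Cc2nnc(CN(c3ccccc3CC)S(=O)(=O)c3ccc(C)cc3)o2)cc1`: 126 nM
- Compound 3, `Cc1ccc(S(=O)(=O)N(Cc2nnc(Cc3ccc(N(C)C)cc3)o2)c2cccc(Cl)c2C)cc1`: 12.6 nM

All three were tested in an assay on CHO cells for displacement of a labelled ligand from prostaglandin E2 receptor EP1 subtype (Homo sapiens); on this read-out higher numbers stand for weaker inhibition and lower numbers for stronger inhibition. Compound 1 was run more than once, and its entries agree closely (the several entries of compound 1 in this assay, 63 nM; 63.1 nM (2 entries)). Compound 3 has the lowest number of the two compounds that share its core; compound 2 sits clearly higher, beyond the scatter of the measurement, so compound 3 is the more potent of that pair. Compound 1 belongs to a different core and is not compared step by step here.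

Compound 4, `Cc1ccc(S(=O)(=O)N(Cc2nnc(Cc3cccc(Cl)c3)o2)c2cccc(Cl)c2C)cc1`, has not yet been measured in this assay. It is made from compound 3 by one change: 3-chlorophenyl in place of 4-(dimethylamino)phenyl on a saturated chain carbon bound to an aromatic carbon. A basic amine-bearing group is thus exchanged for a halogen-bearing one of smaller size, while everything else about the molecule stays the same. Among the compounds with values here, no measured pair in this set shows the effect of such an exchange, so there is no direct guide to how large the step should be.

The expectation is a small shift, most likely toward a somewhat higher number, though a result within the scatter would not surprise; the step from compound 3 to compound 4 is estimated at a 2.0-fold higher number from compound 3 to compound 4 (0.30 log units; within the scatter). Compound 4 is therefore expected to give about 25 nM, with a plausible range from 8 nM to 80 nM.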

Compound 4, half-maximal inhibitory concentration: 158 nM
Estimate against measurement, compound 4: 6.3-fold (0.80 log units) below, and the stated range ends below it.
By their numbers in this assay, from the lowest: compound 3; then compounds 2 and 4 (each within the scatter of the next).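

In this assay, within the data shown here, compounds 3 and 4 form the first pair in this set that differs in only one place, so this is the first direct reading of what that place can contribute: a 13-fold higher number from compound 3 to compound 4 (1.10 log units; beyond the scatter). The step is beyond the scatter and is labelled large, so the group on the saturated chain carbon clearly matters for the measured inhibition, even though the rest of the molecule stays the same. The information at hand does not account for the size of this step.

This single exchange alters two things at once, the substituent on the aromatic ring and its printed ring location, so the compounds shown cannot assign the step to either one, or say whether 4-(dimethylamino)phenyl is especially favourable or 3-chlorophenyl especially unfavourable. A 4-chlorophenyl group and a 3-(dimethylamino)phenyl group at this place would begin to separate these two changes, while an unsubstituted phenyl group would offer a common point of reference for both compounds.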